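Trifluorophenyl replaces chlorophenyl on the pyrrole core

The source may report more compounds than this note shows. Statements on the series, on what has been measured and on what is new or still open speak of the compounds shown alone.

Compound 1 `COc1cc(C(=O)c2cn(-c3ccccc3C)cc2-c2ccccc2)cc(OC)c1OC` and compound 2 `COc1cc(C(=O)c2cn(-c3ccccc3)cc2-c2cccc(Cl)c2)cc(OC)c1OC` share a core; in a functional assay on MCF7 cells (Homo sapiens) for cytotoxicity, read by MTT assay, with a stated time of 96 h (on this read-out lower numbers stand for stronger inhibition and higher numbers for weaker inhibition), compound 1 gives 2200 nM and compound 2 gives 540 nM, so compound 2 stands lowest of the two, with compound 1 beyond the scatter above it. Compound 3 `COc1cc(C(=O)c2cn(-c3ccccc3)cc2-c2c(F)cc(F)cc2F)cc(OC)c1OC` differs from compound 2 by 2,4,6-trifluorophenyl in place of 3-chlorophenyl on an aromatic carbon. Going by the values given here, no measured pair shows this change, so the size of the step is unknown; a moderate rise in this assay is expected, near or just beyond the scatter. Compound 3 is estimated at 1500 nM (range 400 nM to 6000 nM), meaning an expected step of a 2.8-fold higher number from compound 2 to compound 3 (0.44 log units; beyond the scatter).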

Compound 3, half-maximal inhibitory concentration: 180 nM
For compound 3 the middle estimate is 8.3-fold (0.92 log units) above the measured one; measured number outside the range, below it.
By their numbers in this assay, from the lowest: compound 3; then compound 2; then compound 1.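

At this position on the shared core, 2,4,6-trifluorophenyl in place of 3-chlorophenyl gives a 3.0-fold lower number from compound 2 to compound 3 (0.48 log units; beyond the scatter) in this assay, a step beyond the scatter. A ring with three fluorines is therefore accepted here, and the chlorine of compound 2 is not required for activity at this level. Nothing available explains the step.

Whether all three fluorines are needed remains open, since 2,6-difluorophenyl and 4-fluorophenyl are not among the compounds shown. Also open, from the compounds shown here alone, is how this position responds to a methoxy group or an amine on the ring.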